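Truncation of the side chain in a weak bile acid receptor series

The source may hold more compounds than are shown below. What is called first, only, known or untested is meant among the compounds shown, and "the series" means these compounds.

Measured so far:
compound 1 `CC(C)C[C@@H](c1nc2ccc(C(=O)O)cc2n1C)N1C(=O)CN(c2cccc(Oc3ccccc3)c2)C1=O`, 18200 nM in an assay on isolated protein for inhibition of Bile acid receptor (Homo sapiens), read by TR-FRET and LanthaScreen; on this read-out higher numbers stand for weaker inhibition and lower numbers for stronger inhibition
compound 2 `Cn1c([C@H](CC2CCCCC2)N2C(=O)CN(c3ccc(Oc4ccccc4)cc3)C2=O)nc2ccc(C(=O)O)cc21`, 24400 nM

Compound 2 and compound 1 sit within the usual scatter of each other, so neither can be set above the other; both are weak in this assay. Compound 3 `CC[C@@H](c1nc2ccc(C(=O)O)cc2n1C)N1C(=O)CN(c2ccc(Oc3ccccc3)cc2)C1=O` is not yet measured. It differs from compound 2 by methyl in place of cyclohexyl on a saturated chain carbon, two bonds along the chain from an amide-type nitrogen in a ring and an aromatic carbon. Going by the values given here, no measured pair shows this kind of change, so the step is a guess. Given the weak value of compound 2 at 24400 nM, the step of a 1.6-fold higher number from compound 2 to compound 3 (0.21 log units; within the scatter) is expected to be modest and toward a higher number, possibly within the scatter. Compound 3 is estimated at 40000 nM, with a range of 15000 nM to 120000 nM.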

Compound 3, half-maximal inhibitory concentration: 210000 nM
Beside the measured number, compound 3's estimate is 5.3-fold (0.72 log units) below it; measured number above the stated range.
By their numbers in this assay, from the lowest: compounds 1 and 2 (each within the scatter of the next); then compound 3.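

In this assay, going by these compounds alone, replacing cyclohexyl with methyl at this saturated chain carbon gives an 8.6-fold higher number from compound 2 to compound 3 (0.93 log units; beyond the scatter), the first step beyond the scatter. This position therefore affects the read-out, and the cyclohexylmethyl chain of compound 2 holds more inhibition than the ethyl chain of compound 3, although both compounds remain weak. Nothing available explains the size of this step.

From the compounds shown here alone, what a propyl or benzyl group would give at this carbon remains open. So does whether any group here could bring the number below that of compound 2.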